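The compounds below may be only part of what the source reports. "The series", "measured", "known", "first", "only" and "open" are said of these compounds alone.

In a functional assay on the whole organism (strain Swiss albino) for inhibition, with Mus musculus as the target, read by paw edema, with stated times of 30 min and 180 min, at a dose of 100 mg/kg by the subcutaneous route (on this read-out lower numbers stand for less inhibition and higher numbers for more inhibition at the one dose given (going by the name of the read-out)), compound 1 `Cc1ccc(-c2cc(C(=O)Oc3ccc(C(C)C)cc3)n(Cc3ccccc3)n2)cc1` gives 24%. Compound 2 `Cc1ccc(-c2cc(C(=O)Oc3ccc(C(C)(C)C)cc3)nn2Cc2ccccc2)cc1` gives 28.5% in this assay, a number that lies within the usual scatter of the value of compound 1, so the two compounds cannot be told apart on these data. Compound 3 `Cc1ccc(-c2cc(C(=O)Oc3ccc(C(C)C)cc3)nn2Cc2ccccc2)cc1` has not yet been measured. It differs from compound 2 by hydrogen in place of methyl on a saturated chain carbon bound to an aromatic carbon and two saturated chain carbons. Among the measured compounds shown here, no measured pair shows what this change brings, so the expected step of a number 2.5 percentage points lower from compound 2 to compound 3 (within the scatter) is small and not beyond the scatter. Compound 3 is expected to give 26%, in the range from 16% to 36%.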

Compound 3, a percentage reported as inhibition, in the whole organism at one dose (the size of the read-out at that dose, not a potency): 18.7%
Compound 3: middle estimate off by 7.3 percentage points, on the high side, within the range that was stated.
By their numbers in this assay, from the lowest: compounds 3, 1 and 2 (each within the scatter of the next).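

In this assay, replacing one methyl with hydrogen on this saturated chain carbon turns tert-butyl into isopropyl and gives a number 9.8 percentage points lower from compound 2 to compound 3 (within the scatter). Among the compounds shown here, this is the first measured step at this position, and it shows that this single change does not separate the two compounds on these data. Nothing available gives a reason for this result.

As far as these compounds go, whether a different group at this place, such as a methoxy group, a carboxylic acid or a longer chain like n-hexyl, would give a step beyond the scatter remains open.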